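Chalcone series on prostate cancer cells: nitro to chloro swap

The source may report more compounds than this note shows. Statements on the series, on what has been measured and on what is new or still open speak of the compounds shown alone.

Measured so far:
- compound 1 `CC1(C)Cc2c(O)ccc(C(=O)/C=C/c3cn(-c4ccccc4)nc3-c3cccc([N+](=O)[O-])c3)c2O1` gives 25600 nM in a functional assay on PC-3 cells (Homo sapiens) for antiproliferative activity, read by MTT assay, with a stated time of 48 h; a lower number here means a stronger inhibitor, a higher number a weaker inhibitor
- compound 2 `CC1(C)Cc2c(OCc3ccccc3)ccc(C(=O)/C=C/c3ccc(Cl)cc3Cl)c2O1` gives only a limit of this assay, > 100000 nM
- compound 3 `CC1(C)Cc2c(ccc(C(=O)/C=C/c3cn(-c4ccccc4)nc3-c3ccccc3)c2OCc2ccccc2)O1` gives only a limit of this assay, > 100000 nM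

Three compounds are in hand. For the measured compounds named here, compound 1 is the only one with a numerical value; the two others stop at the limit of the assay, and the limit of > 100000 nM in this assay, at which 2 of the 3 values shown sit, states that limit. Going by the values given here, compound 1 therefore stands as the sole quantified point of the series; compounds 2 and 3 carry a benzyl ether on the shared core where compound 1 carries a free hydroxyl, and no step between any two of the measured compounds can be quantified.

Compound 4 `CC1(C)Cc2c(O)ccc(C(=O)/C=C/c3cn(-c4ccccc4)nc3-c3ccc(Cl)cc3)c2O1` keeps the free hydroxyl of compound 1 and changes the aryl group on the pyrazole: 4-chlorophenyl in place of 3-nitrophenyl on an aromatic carbon. Among the compounds with values here, no measured step of this kind exists in the set, so the direction of the change is open. The expectation is a small step, within or close to the scatter, with compound 4 estimated near compound 1 rather than at the limit. Compound 4 is expected to give 30000 nM, with a range from 8000 nM to 100000 nM. The estimated step from compound 1 to compound 4 is a 1.2-fold higher number from compound 1 to compound 4 (0.07 log units; within the scatter).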

Compound 4, half-maximal inhibitory concentration: 18000 nM
Compound 4: the middle estimate sits 1.7-fold (0.22 log units) above what was measured, and the stated range covers the measured number.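

For the compounds shown here, the first readable step in this assay is a 1.4-fold lower number from compound 1 to compound 4 (0.15 log units; within the scatter), on exchanging 3-nitrophenyl for 4-chlorophenyl with the free hydroxyl and the rest of the shared core kept. At this aromatic carbon of the five-membered aromatic ring with 2 nitrogen, the entering group has no hydrogen-bond acceptors and the leaving group has 2, yet the two numbers stay within the scatter of each other. Compound 1 is therefore no longer the only quantified point, and in this one pair the measured activity does not rest on the 3-nitrophenyl group.

From the compounds shown here alone, the steps to compound 2 and compound 3 cannot be read, as each of the two compounds gives only a limit and each also differs from compound 1 and compound 4 in more than one place: the limit of > 100000 nM in this assay, at which 2 of the 4 values shown sit. Still open are what a 4-aminophenyl or a 4-carboxyphenyl group would give at this position, and what a methyl ether in place of the free hydroxyl would give with the aryl group held fixed.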